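Compound 3 to compound 4: a step from a limit

The compounds below may be only part of what the source reports. "The series", "measured", "known", "first", "only" and "open" are said of these compounds alone.

Measured so far in a functional assay on HepG2 cells (Homo sapiens) for cytotoxicity, with a stated time of 72 h; on this read-out higher numbers stand for an effect only at larger amounts of compound and lower numbers for an effect already at smaller amounts:
Compound 1 (`C=C[C@@](C)(/C=C/c1ccc(Nc2ccc(OC)cc2)cc1)CCC=C(C)C`): > 52000 nM, a limit
Compound 2 (`C=C[C@@](C)(/C=C/c1ccc(Nc2cc(F)cc(F)c2)cc1)CCC=C(C)C`): > 52000 nM, a limit
Compound 3 (`C=C[C@@](C)(/C=C/c1ccc(Nc2ccc(Cl)cc2)cc1)CCC=C(C)C`): > 52000 nM, a limit

None of these three compounds has an exact number, and the data so far end at the limit of > 52000 nM in this assay, at which 3 of the 3 values shown sit. Compound 3 stands there with the others, and its > 52000 nM is a limit.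

In compound 4 (`C=C[C@@](C)(/C=C/c1ccc(-c2ccc(F)cc2)cc1)CCC=C(C)C`), 4-fluorophenyl stands in place of (4-chlorophenyl)amino on an aromatic carbon, and the counted difference is 4-fluorophenyl in place of (4-chlorophenyl)amino on an aromatic carbon. The measured steps that come closest only exchange the group on the nitrogen: a step that the two limits leave unreadable from compound 1 to compound 2, a step that the two limits leave unreadable from compound 1 to compound 3 and a step that the two limits leave unreadable from compound 2 to compound 3. None of them has a readable size, and none removes the nitrogen, so they offer only weak guidance for this change.

With no measured shift to build on, no step beyond the usual scatter is expected in this assay, in either direction, and another limit is the likeliest report. The expected step is an at least 1.0-fold lower number from compound 3 to compound 4 (0.01 log units; that floor lies within the scatter). For compound 4 the estimated value is 50000 nM, with an expected range from 22000 nM to 100000 nM.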

Compound 4, half-maximal effective concentration: > 52000 nM
Compound 4 ended at the assay's limit; the forecaster's own chance of this, stated with the estimate: 70%; at least 1.0-fold (0.01 log units) between middle value and limit.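

In this assay compound 4 gives > 52000 nM, which is a limit. The steps to compound 4 from compound 1, compound 2 and compound 3 cannot be read, because all four compounds end in the same place: the limit of > 52000 nM in this assay, at which 4 of the 4 values shown sit.

The compounds shown leave open how far each one lies from that limit, and whether any of these group exchanges on the shared core changes the effect at all.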